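Series notes: aryl variation on the saturated ring carbon

This account rests on a few compounds, and the source may have more. Where it says the series, first, only, none or still open, it means among the compounds named here.

Of the compounds shown here, three sharing one core have been measured in a functional assay on Ehrlich cells (Mus musculus) for cytotoxicity, tested at 10 ug/mL; a lower number here means a weaker effect, a higher number a stronger effect of the compound at the concentration tested. Compound 1 `COc1cc(N2C(N)=C(C#N)C(c3cccc([N+](=O)[O-])c3)C3=C2CC(C)(C)CC3=O)cc(OC)c1OC` gives 5% in this assay. Compound 2 `COc1cc(N2C(N)=C(C#N)C(c3c(OC)ccc4ccccc34)C3=C2CC(C)(C)CC3=O)cc(OC)c1OC`, carrying 2-methoxynaphthalen-1-yl in place of 3-nitrophenyl on the saturated ring carbon, gives 0% in this assay. Compound 3 `COc1cc(N2C(N)=C(C#N)C(/C=C/c3ccccc3)C3=C2CC(C)(C)CC3=O)cc(OC)c1OC` gives 10% in this assay. On the numbers shown compound 3 sits at the upper end of the three, but this rests on a number 5 percentage points higher from compound 1 to compound 3 (within the scatter) and on a number 10 percentage points higher from compound 2 to compound 3 (within the scatter), neither of which is beyond the scatter, and the remaining pair, a number 5 percentage points lower from compound 1 to compound 2 (within the scatter), is likewise within it. All three measured groups on that carbon therefore give read-outs that cannot be told apart.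

Compound 4 `COc1cc(N2C(N)=C(C#N)C(c3ccccc3)C3=C2CC(C)(C)CC3=O)cc(OC)c1OC` is the next member. phenyl in place of 2-phenylethenyl on a saturated ring carbon

Every measured step in the series changes the group on this same saturated ring carbon, and none of them moved this assay beyond the scatter; a phenyl in place of 2-phenylethenyl is a smaller change than any of those. No step beyond the scatter is therefore expected for a number 5 percentage points lower from compound 3 to compound 4 (within the scatter). Compound 4 is expected to give about 5% in this assay, within a range of 0% to 15%.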

Compound 4, a percentage reported as activity, at one concentration (the size of the read-out at that concentration, not a potency): 0%
Compound 4: middle estimate off by 5 percentage points, on the high side; the measured number falls inside the stated range.
By their numbers in this assay, from the lowest: compounds 2, 4, 1 and 3 (each within the scatter of the next).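

In this assay, among the compounds shown here, the unsubstituted phenyl extends the set of groups on the saturated ring carbon, and neither the step reading a number 10 percentage points lower from compound 3 to compound 4 (within the scatter) nor the one reading no change at the digits printed from compound 2 to compound 4 (within the scatter) separates it from the larger 2-phenylethenyl or 2-methoxynaphthalen-1-yl groups. This compound also gives the series its first comparison on the aromatic ring itself: hydrogen in place of nitro gives a number 5 percentage points lower from compound 1 to compound 4 (within the scatter) and so leaves the read-out indistinguishable, which means the four groups now shown on this carbon form one flat set within the scatter in this assay, with no size or substituent trend to be drawn from compounds 1 to 4. No information is available that would account for this flat set of read-outs.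

Still open, from the compounds shown here alone, is whether any group on this carbon can lift the read-out beyond the scatter, for example a phenyl bearing an amine or a carboxylic acid, or a saturated alkyl chain in place of the aromatic ring. Equally open, going by these compounds, is whether a change away from this carbon, such as replacing the 3,4,5-trimethoxyphenyl group on the ring nitrogen, would move this assay at all.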